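The source may hold more compounds than are shown below. What is called first, only, known or untested is meant among the compounds shown, and "the series" means these compounds.

Working notes on a small set measured in a functional assay on MKN-45 cells (Homo sapiens) for cytotoxicity, read by MTT assay, with a stated time of 72 h; a lower number here means a stronger inhibitor, a higher number a weaker inhibitor.

Compound 1 `Fc1ccc(Nc2cc(Nc3ccc(Oc4ccncc4-c4cccnc4)c(F)c3)ncn2)cc1F` gives 80 nM in this assay. Compound 2 `Fc1ccc(Nc2cc(Nc3ccc(Oc4ccncc4-c4cccnc4)c(F)c3)ncn2)cc1` gives 160 nM in this assay. For the measured compounds named here, the two differ by hydrogen in place of fluoro on an aromatic carbon, at a place on an aromatic carbon of a six-membered aromatic ring of carbon only, ortho to a fluoro group and meta to a large group; the step of a 2.0-fold higher number from compound 1 to compound 2 (0.30 log units; within the scatter) is the only directly comparable pair in the set.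

Compound 3 `O=C(Nc1ccc(Oc2ccncc2-c2cccnc2)c(F)c1)c1nn(-c2cccc(F)c2)c(=O)c2ccccc12` gives 27 nM in this assay, the strongest number here, with both its neighbours beyond the scatter. The difference between the core of compound 3 and the core of compound 1 is not broken down here.

Compound 4 `O=C(Nc1ccc(Oc2ccncc2-c2cccnc2)c(F)c1)c1nn(-c2ccccc2)c(=O)c2ccccc12` is not yet measured. It differs from compound 3 by hydrogen in place of fluoro on an aromatic carbon, at a place on an aromatic carbon of a six-membered aromatic ring of carbon only, meta to a large group. Around the place the surroundings differ: in the pair compound 1 to compound 2 the carbon was also ortho to a fluoro group, which is absent in compound 3. The change is therefore the same kind of change as that from compound 1 to compound 2, not the same.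

The expectation for compound 4 rests on compound 3 at 27 nM and on the size of a 2.0-fold higher number from compound 1 to compound 2 (0.30 log units; within the scatter), and so compound 4 is expected to move by about a 1.7-fold higher number from compound 3 to compound 4 (0.22 log units; within the scatter). Compound 4 is accordingly estimated at 45 nM, with a range from 18 nM to 110 nM, on the single comparable step shown.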

Compound 4, half-maximal inhibitory concentration: 90 nM
The estimate for compound 4 lay 2.0-fold (0.30 log units) below the measured number, and the stated range covers the measured number.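

In this assay, hydrogen in place of fluoro on the core of compound 3, the change from 3-fluorophenyl to phenyl, gives a 3.3-fold higher number from compound 3 to compound 4 (0.52 log units; beyond the scatter), a step that can be read as a real loss on this core. Set beside the earlier step on the core of compound 1, the size of the change does not separate the two cores: the same change on two cores in this assay, a 2.0-fold higher number (0.30 log units; within the scatter) from compound 1 to compound 2 and a 3.3-fold higher number (0.52 log units; beyond the scatter) from compound 3 to compound 4, 1.7-fold (0.22 log units) apart, within the scatter of two such steps

So, within this series, the size seen on one core is a usable guide to the size on the other, but two pairs do not fix a general size for the change, one of the two steps lies within the scatter, the surroundings of the carbon differ between the pairs, and nothing here explains the result.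

The compounds shown leave open whether a chloro, methyl or methoxy group on the same aromatic carbon would read like fluoro or like hydrogen on either core. Also open, on these data alone, is how an amine or a carboxylic acid at that place would read in this assay, and whether any such replacement would carry from one core to the other as this one does.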